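Three carbamates with level inhibition numbers and a fourth awaiting its cell read-out

This account rests on a few compounds, and the source may have more. Where it says the series, first, only, none or still open, it means among the compounds named here.

Compound 1 `COc1ccc(NC(=O)Oc2cc(=O)n(CCCO)c3c2CC(CC=C(C)C)C(C)(C)C3)cc1` is tested in a functional assay on PANC-1 cells (Homo sapiens) for inhibition, read by MTT assay, with a stated time of 24 h, tested at 10 uM (a lower number here means less inhibition, a higher number more inhibition at the concentration tested (going by the name of the read-out)), where compound 1 gives 0%. Compound 2 `COc1cccc(NC(=O)Oc2cc(=O)n(CCCO)c3c2CC(CC=C(C)C)C(C)(C)C3)c1` carries the change (3-methoxyphenyl in place of 4-methoxyphenyl on an amide-type nitrogen), and in this assay compound 2 gives 0%, so that the step of no change at the digits printed from compound 1 to compound 2 (within the scatter). Compound 3 `COc1ccc(NC(=O)Oc2cc(=O)n(CCCO)c3c2CC(C/C=C(\C)CCC=C(C)C)C(C)(C)C3)cc1` differs from compound 1 in its core by 3-methylbut-2-en-1-yl in place of hydrogen on a saturated chain carbon bound to a double-bonded chain carbon; in this assay compound 3 gives 0%, and the step of no change at the digits printed from compound 1 to compound 3 (within the scatter). Compound 4 `COc1cccc(NC(=O)Oc2cc(=O)n(CCCO)c3c2CC(C/C=C(\C)CCC=C(C)C)C(C)(C)C3)c1` has not yet been measured in this assay. For the measured compounds named here, it stands to compound 3 as compound 2 stands to compound 1: the change (3-methoxyphenyl in place of 4-methoxyphenyl on an amide-type nitrogen), made at the same place, so it is the same change as the one from compound 1 to compound 2, only on the core of compound 3. That earlier step produced no change, and the core change from compound 1 to compound 3 also produced none. On this basis compound 4 is expected to show 0%, with a range from -5% to 10%, meaning an expected step of no change at the digits printed from compound 3 to compound 4 (within the scatter).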

Compound 4, a percentage reported as inhibition, at one concentration (the size of the read-out at that concentration, not a potency): 11.3%
For compound 4 the middle estimate is 11.3 percentage points below the measured one, and the stated range ends below it.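

In this assay, 3-methoxyphenyl in place of 4-methoxyphenyl on the amide-type nitrogen gives a number 11.3 percentage points higher from compound 3 to compound 4 (beyond the scatter), and 3-methylbut-2-en-1-yl in place of hydrogen on the saturated chain carbon gives a number 11.3 percentage points higher from compound 2 to compound 4 (beyond the scatter). Although only the step on the core of compound 3 lies beyond the scatter, the methoxyphenyl change on the two cores does not separate clearly: the same change on two cores in this assay, no change at the digits printed (within the scatter) from compound 1 to compound 2 and a number 11.3 percentage points higher (beyond the scatter) from compound 3 to compound 4, 11.3 percentage points apart, within the scatter of two such steps The chain change reads the same way, so the compounds do not establish that either change depends on the core, nor do they show that either carries over unaltered, since each comparison rests on a single pair of steps: the same change on two cores in this assay, no change at the digits printed (within the scatter) from compound 1 to compound 3 and a number 11.3 percentage points higher (beyond the scatter) from compound 2 to compound 4, 11.3 percentage points apart, within the scatter of two such steps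

The compounds shown leave open whether an amine or a carboxylic acid in place of the methoxy group, or a longer chain in place of the 3-methylbut-2-en-1-yl group, would alter the number in this assay. They also leave open the potency of compound 4, since the read-out comes from a single concentration.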